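Two thiosemicarbazones at the tolerance limit, a third expected

The source may report more compounds than this note shows. Statements on the series, on what has been measured and on what is new or still open speak of the compounds shown alone.

Compound 1, `O=C1Nc2ccccc2/C1=N/NC(=S)N1CCCC1`, in an ADME assay on RD cells (Homo sapiens) for cytotoxicity; a lower number here means that less compound is tolerated, a higher number that more compound is tolerated: > 25000 nM, a limit of the assay.
Compound 2, `O=C1Nc2ccc(Cl)cc2/C1=N/NC(=S)Nc1ccccc1`, in this assay: > 25000 nM, also a limit of the assay.

Compound 1 therefore has no number in this assay, only a limit. Compound 2 has only a limit as well, and both sit at the same place, (the limit of > 25000 nM in this assay, at which 2 of the 2 values shown sit). Among the compounds with values here, no step between measured compounds can be read from these two, since the change from compound 1 to compound 2 touches two places and neither has a number.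

Compound 3, `CCNC(=S)N/N=C1\C(=O)Nc2ccccc21`, is not yet measured. It differs from compound 1 by ethylamino in place of pyrrolidin-1-yl on a thiocarbonyl carbon. The shared core of compound 1 is kept.

Since compound 1 gives only a limit, the step to compound 3 in this assay is expected to be none beyond the scatter, with compound 3 expected to sit at the same limit, a step that the limit leaves unreadable from compound 1 to compound 3. Compound 3 is estimated at 40000 nM, between 15000 nM and 150000 nM.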

Compound 3, half-maximal cytotoxic concentration: > 25000 nM
Compound 3 was reported as a limit; the forecaster's own chance of this, stated with the estimate: 75%; the middle value is on the limit's open side.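

Compound 1 and compound 3 both give only a limit in this assay, so no step can be read from the exchange of pyrrolidin-1-yl for ethylamino: the limit of > 25000 nM in this assay, at which 3 of the 3 values shown sit.

The compounds shown leave open whether any change to the shared core alters the half-maximal cytotoxic concentration in this assay, as none of them gives a number there.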